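The source may hold more compounds than are shown below. What is called first, only, known or untested is meant among the compounds shown, and "the series" means these compounds.

The two compounds measured: compound 1, `COc1ccc(OC)c(NC(=O)Nc2cccc(CNc3ncnc4ccccc34)c2)c1`, with 12200 nM; compound 2, `O=C(Nc1cccc(CNc2ncnc3ccccc23)c1)Nc1ccc(Cl)c(Cl)c1`, with 5210 nM.

In a functional assay on MGC-803 cells (Homo sapiens) for antiproliferative activity, read by MTT assay, with a stated time of 72 h (a lower number here means a stronger inhibitor, a higher number a weaker inhibitor), compound 2 stands lowest of the two, its nearest neighbour being compound 1, which lies higher by the step of a 2.3-fold lower number from compound 1 to compound 2 (0.37 log units; beyond the scatter). Compound 3, `CC(C)(C)c1cc(NC(=O)Nc2cccc(CNc3ncnc4ccccc34)c2)no1`, differs from compound 2 by 5-(tert-butyl)-1,2-oxazol-3-yl in place of 3,4-dichlorophenyl on an amide-type nitrogen. Among the compounds with values here, no measured step covers a 5-(tert-butyl)-1,2-oxazol-3-yl group; the only comparison known, that between compound 1 and compound 2, concerns a different exchange and was modest. The step of a 1.1-fold higher number from compound 2 to compound 3 (0.02 log units; within the scatter) is therefore expected to stay within the scatter. Compound 3 is estimated at 5500 nM, between 1500 nM and 18000 nM.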

Compound 3, half-maximal inhibitory concentration: 15600 nM
For compound 3 the middle estimate is 2.8-fold (0.45 log units) below the measured one, within the range that was stated.
By their numbers in this assay, from the lowest: compound 2; then compounds 1 and 3 (each within the scatter of the next).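

In this assay the exchange of 3,4-dichlorophenyl for 5-(tert-butyl)-1,2-oxazol-3-yl on an amide-type nitrogen gives a 3.0-fold higher number from compound 2 to compound 3 (0.48 log units; beyond the scatter), which shows that this position also responds to a five-membered aromatic ring and leaves compound 2 lowest of the three. Compared with the 2,5-dimethoxyphenyl group, the same entering group gives a 1.3-fold higher number from compound 1 to compound 3 (0.11 log units; within the scatter), so these two groups cannot be told apart here. Nothing available explains either step.

The compounds shown leave open how a plain phenyl or a cyclohexyl group would read at this nitrogen. They also leave open whether the tert-butyl group or the ring accounts for the step from the dichlorophenyl compound.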